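Naphthyl ether variation and cytotoxicity tolerance

A few compounds are considered here, and "the series" means these few. Any claim that something is new, unique, unknown or untested is made for them only; others in the source may bear on it.

Compound 1 `Cc1cc(S(N)(=O)=O)ccc1NC(=O)COc1ccc(F)cc1Oc1cccc2ccccc12` gives 33100 nM in an ADME assay on C8166 cells (Homo sapiens) for cytotoxicity, read by MTT assay; a lower number here means that less compound is tolerated, a higher number that more compound is tolerated. Compound 2 `Cc1cc(S(N)(=O)=O)ccc1NC(=O)COc1ccc(F)cc1Oc1cc2ccccc2cc1C` gives 66900 nM in this assay, and compound 3 `Cc1cc(S(N)(=O)=O)ccc1NC(=O)COc1ccc(F)cc1Oc1ccc2ccccc2c1Cl` gives 47100 nM. Going by the values given here, the only step beyond the scatter is a 2.0-fold higher number from compound 1 to compound 2 (0.31 log units; beyond the scatter); both a 1.4-fold higher number from compound 1 to compound 3 (0.15 log units; within the scatter) and a 1.4-fold lower number from compound 2 to compound 3 (0.15 log units; within the scatter) stay within it. Compound 3 thus stands second highest of the three, within the scatter of both other compounds. Compound 4 `Cc1cc(S(N)(=O)=O)ccc1NC(=O)COc1ccc(F)cc1Oc1ccc2cc(Br)ccc2c1Cl` differs from compound 3 by bromo in place of hydrogen on an aromatic carbon. Among the compounds with values here, no measured step adds a halogen to the aryl group on the ether oxygen without also changing that group's attachment; the closest comparison is a 1.4-fold higher number from compound 1 to compound 3 (0.15 log units; within the scatter), which was small. In this assay the expected step is therefore a 1.1-fold higher number from compound 3 to compound 4 (0.03 log units; within the scatter), nothing beyond the scatter. The estimate for compound 4 is 50000 nM, with a range from 25000 nM to 100000 nM.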

Compound 4, half-maximal cytotoxic concentration: 195000 nM
Compound 4: the middle estimate sits 3.9-fold (0.59 log units) below what was measured; the measured number lies above the stated range.
By their numbers in this assay, from the lowest: compounds 1, 3 and 2 (each within the scatter of the next, the first and the last beyond it); then compound 4.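

In this assay, going by these compounds alone, bromo in place of hydrogen on the 1-chloronaphthalen-2-yl group gives a 4.1-fold higher number from compound 3 to compound 4 (0.62 log units; beyond the scatter) and is the first step here that adds an atom to the aryl group without changing its attachment. The 6-bromo-1-chloronaphthalen-2-yl group also stands clear of the other aryl groups, with a 2.9-fold higher number from compound 2 to compound 4 (0.46 log units; beyond the scatter) and a 5.9-fold higher number from compound 1 to compound 4 (0.77 log units; beyond the scatter) as the further steps. Nothing available explains the size of these steps.

As far as these compounds go, whether fluoro, methyl or an amine on the same carbon gives a similar step remains open. Also open, from the compounds shown here alone, is whether bromo gives this step without the 1-chloro group.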